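A few compounds are considered here, and "the series" means these few. Any claim that something is new, unique, unknown or untested is made for them only; others in the source may bear on it.

Three compounds share one core and differ only in the aryl group sitting on an oxygen on a saturated carbon. In a functional assay on Ehrlich cells (Mus musculus) for cytotoxicity, read by trypan blue exclusion, with a stated time of 48 h (on this read-out lower numbers stand for stronger inhibition and higher numbers for weaker inhibition), compound 1 `Cc1cc(OCC(=O)Nc2nc(-c3ccc(Br)cc3)cs2)ccc1Cl` gives 47100 nM, compound 2 `O=C(COc1ccccc1)Nc1nc(-c2ccc(Br)cc2)cs1` gives 37100 nM, and compound 3 `Cc1ccccc1OCC(=O)Nc1nc(-c2ccc(Br)cc2)cs1` gives 44500 nM, which places compound 3 second highest of the three numbers, its nearest neighbour being a 1.1-fold lower number from compound 1 to compound 3 (0.02 log units; within the scatter) and its furthest a 1.2-fold higher number from compound 2 to compound 3 (0.08 log units; within the scatter). Compound 4 `Cc1ccc(OCC(=O)Nc2nc(-c3ccc(Br)cc3)cs2)cc1` differs from compound 3 by 4-methylphenyl in place of 2-methylphenyl on an oxygen on a saturated carbon. Going by the values given here, the steps that bear on this change, a 1.3-fold lower number from compound 1 to compound 2 (0.10 log units; within the scatter) and a 1.2-fold higher number from compound 2 to compound 3 (0.08 log units; within the scatter), all stay within the scatter, so no step beyond the scatter is expected in this assay in either direction. Compound 4 is therefore estimated at 42000 nM, with a range of 20000 nM to 90000 nM, meaning an expected step of a 1.1-fold lower number from compound 3 to compound 4 (0.03 log units; within the scatter).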

Compound 4, half-maximal inhibitory concentration: 55300 nM
For compound 4 the middle estimate is 1.3-fold (0.12 log units) below the measured one; the range from low to high includes it.
By their numbers in this assay, from the lowest: compounds 2, 3, 1 and 4 (each within the scatter of the next).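

In this assay, 4-methylphenyl in place of 2-methylphenyl on an oxygen on a saturated carbon gives a 1.2-fold higher number from compound 3 to compound 4 (0.09 log units; within the scatter), so the two methylphenyl groups are not told apart here. The two further steps, a 1.5-fold higher number from compound 2 to compound 4 (0.17 log units; within the scatter) and a 1.2-fold higher number from compound 1 to compound 4 (0.07 log units; within the scatter), also stay within the scatter, so compound 4 is not separated from the unsubstituted phenyl or the 4-chloro-3-methylphenyl compound either. Nothing available accounts for these results.

The compounds shown leave open whether an amine or a carboxylic acid on this aryl ring, or a longer chain bearing the aryloxy group, would give a step beyond the scatter.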